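Methoxy for Bromo on a Doubly Limited Pair

The compounds below may be only part of what the source reports. "The series", "measured", "known", "first", "only" and "open" are said of these compounds alone.

Compound 1 `Fc1ccc(-c2nc3sc(Cc4ccc(Cl)cc4)nn3c2Br)cc1` and compound 2 `Clc1ccc(Cc2nn3c(Br)c(-c4ccc(Br)cc4)nc3s2)cc1` share one core and differ only on a phenyl ring. In a functional assay on L1210 cells (Mus musculus) for cytotoxicity, with a stated time of 48 h (on this read-out lower numbers stand for stronger inhibition and higher numbers for weaker inhibition), compound 1 gives no number, only a limit of the assay, > 250000 nM. In this assay compound 2 likewise gives only a limit, > 250000 nM. Within the data shown here, the single measured step, a step that the two limits leave unreadable from compound 1 to compound 2, is therefore unreadable in size; both values sit at the limit of > 250000 nM in this assay, at which 2 of the 2 values shown sit. Compound 3 `COc1ccc(-c2nc3sc(Cc4ccc(Cl)cc4)nn3c2Br)cc1` differs from compound 2 by methoxy in place of bromo on an aromatic carbon. Among the measured compounds shown here, no measured step bears on this change with a readable size, and compound 2 stands at the limit rather than at a number. Compound 3 is thus expected to stay at the same limit in this assay, a step of a number no higher from compound 2 to compound 3 (the limit leaves the size open) that would amount to nothing beyond the scatter. The estimate for compound 3 is 250000 nM, with a range from 100000 nM to 600000 nM.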

Compound 3, half-maximal inhibitory concentration: 63000 nM
For compound 3 the middle estimate is 4.0-fold (0.60 log units) above the measured one, outside the stated range (below it).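

At this position, on an aromatic carbon para to a large group, the change from 4-bromophenyl to 4-methoxyphenyl gives the first readable movement in this assay: it is an at least 3.9-fold lower number from compound 2 to compound 3 (0.59 log units; beyond the scatter) and, with methoxy replacing fluoro, an at least 3.9-fold lower number from compound 1 to compound 3 (0.59 log units; beyond the scatter). The earlier pair could not show that this ring position affects the read-out at all, since neither halogen compound gave a number. Compound 3 alone has a number, so both steps set only a minimum size, and the two halogen compounds remain at a limit of the assay: the limit of > 250000 nM in this assay, at which 2 of the 3 values shown sit.

The step from compound 1 to compound 2 cannot be read, so fluoro and bromo cannot be ranked. Going by these compounds, whether a hydroxyl, an amine or a longer chain such as ethoxy at this place would lower the number further, or return it to the limit, remains open.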